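This account rests on a few compounds, and the source may have more. Where it says the series, first, only, none or still open, it means among the compounds named here.

Measured compounds:
Compound 1 `Cc1ccc(-n2nncc2CN2C(=O)C3(C(C#N)=C(N)Oc4c(N)cc5nc6ccccc6nc5c43)c3ccccc32)cc1C` — in a functional assay on HCT-116 cells (Homo sapiens) for antiproliferative activity, read by MTT assay, with a stated time of 48 h (on this read-out higher numbers stand for weaker inhibition and lower numbers for stronger inhibition), compound 1 gives > 50000 nM, a limit of the assay and not a number.
Compound 2 `CCc1cccc(CC)c1-n1nncc1CN1C(=O)C2(C(C#N)=C(N)Oc3c(N)cc4nc5ccccc5nc4c32)c2ccccc21` — in this assay compound 2 gives 37600 nM.
Compound 3 `COc1ccc(OC)c(-n2nncc2CN2C(=O)C3(C(C#N)=C(N)Oc4c(N)cc5nc6ccccc6nc5c43)c3ccccc32)c1` — in this assay compound 3 gives > 50000 nM, again a limit of the assay and not a number.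

Compound 3 stands at the limit of this assay. Compound 1 stands at the same limit, which is the limit of > 50000 nM in this assay, at which 2 of the 3 values shown sit. Compound 2 alone gives a number. The step of an at least 1.3-fold lower number from compound 1 to compound 2 (0.12 log units; that floor lies within the scatter) and the step of an at least 1.3-fold higher number from compound 2 to compound 3 (0.12 log units; that floor lies within the scatter) are both floors that lie within the scatter, and the step that the two limits leave unreadable from compound 1 to compound 3 cannot be read from two limits. Across the three aryl groups on the aromatic nitrogen the series sits at or close to the limit throughout.

Compound 4 `N#CC1=C(N)Oc2c(N)cc3nc4ccccc4nc3c2C12C(=O)N(Cc1cnnn1-c1ccc([N+](=O)[O-])cc1[N+](=O)[O-])c1ccccc12` differs from compound 3 by 2,4-dinitrophenyl in place of 2,5-dimethoxyphenyl on an aromatic nitrogen. All three measured steps bear on exchanging the aryl group at this position, and none of them shows a movement beyond the scatter. Compound 4 is therefore expected to stay at or near the limit, and the step of a number no higher from compound 3 to compound 4 (the limit leaves the size open) is expected to be no larger than the scatter. The estimate for compound 4 in this assay is 50000 nM, with a range from 20000 nM to 200000 nM, and a limit rather than a number is the more likely report.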

Compound 4, half-maximal inhibitory concentration: 23900 nM
Compound 4: the middle estimate sits 2.1-fold (0.32 log units) above what was measured; the range from low to high includes it.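

In this assay, among the compounds shown here, exchanging the aryl group on the aromatic nitrogen now moves the read-out beyond the scatter for the first time, with 2,4-dinitrophenyl giving an at least 2.0-fold lower number from compound 3 to compound 4 (0.32 log units; beyond the scatter) and an at least 2.0-fold lower number from compound 1 to compound 4 (0.32 log units; beyond the scatter). Both steps are floors and not sizes because each starts from a limit and not a number: the limit of > 50000 nM in this assay, at which 2 of the 4 values shown sit. The same group gives a 1.6-fold lower number from compound 2 to compound 4 (0.20 log units; within the scatter), so compound 4 is separated from compound 1 and compound 3 but not from compound 2, and this position responds to the aryl exchange only to a modest readable extent, with compound 4 at 23900 nM.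

The compounds shown leave open whether the two nitro groups act together or one alone carries the step, which a 4-nitrophenyl or 2-nitrophenyl group would test, and whether an amine or a carboxylic acid on this phenyl ring, or a longer alkyl chain in place of the ring, would move the read-out further from the limit. As far as these compounds go, how far compound 1 and compound 3 actually lie past their limit also stays open, and with it the true size of their steps to compound 4.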